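The source may hold more compounds than are shown below. What is called first, only, known or untested is meant among the compounds shown, and "the series" means these compounds.

Measured compounds in a functional assay on HeLa cells (Homo sapiens) for cytotoxicity, read by MTT assay, with a stated time of 24 h; a higher number here means a weaker inhibitor, a lower number a stronger inhibitor:
compound 1 `Cc1cc(O)c(C(=O)/C=C/c2ccccc2)c(-c2ccc(Br)cc2)c1C(=O)/C=C/c1ccccc1` gives 30000 nM
compound 2 `Cc1cc(O)c(C(=O)/C=C/c2ccc(F)cc2)c(-c2ccc(OCc3ccccc3)cc2)c1C(=O)/C=C/c1ccc(F)cc1` gives 25000 nM
compound 3 `COc1ccc(/C=C/C(=O)c2c(C)cc(O)c(C(=O)/C=C/c3ccc(OC)c(OC)c3)c2-c2ccc(OCc3ccccc3)cc2)cc1OC` gives "not active" (no number reported)

Compound 3 returned no number; it is recorded only as not active. Of the two numbers in hand, compound 2 stands lowest, but its gap to compound 1 lies within the scatter, so the two cannot be ordered. For the measured compounds named here, no single-change step between measured compounds is available in this set.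

Compound 4 `Cc1cc(O)c(C(=O)/C=C/c2ccc(F)cc2)c(-c2ccccc2)c1C(=O)/C=C/c1ccc(F)cc1` is the next entry. Relative to compound 2 the change is hydrogen in place of benzyloxy on an aromatic carbon; the remaining parts of the shared core and both side chains are unchanged.

Going by the values given here, with no step between measured compounds to lean on, the expectation rests on the spread seen so far: compound 1 and compound 2 sit close together despite differing groups at the same aromatic position, and compound 3 gave no number at all. For compound 4 the step from compound 2 is therefore expected to be small, a 1.2-fold higher number from compound 2 to compound 4 (0.08 log units; within the scatter), in no fixed direction beyond the scatter. Compound 4 is estimated at 30000 nM, with a range from 12000 nM to 80000 nM.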

Compound 4, half-maximal inhibitory concentration: 30000 nM
The estimate for compound 4 equals the measured number at the digits printed, and the stated range covers the measured number.
By their numbers in this assay, from the lowest: compounds 2, 1 and 4 (each within the scatter of the next).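

In this assay, for the compounds shown here, the only single-change step, hydrogen in place of benzyloxy on an aromatic carbon para to a large group, gives a 1.2-fold higher number from compound 2 to compound 4 (0.08 log units; within the scatter). With both side chains and the rest of the shared core unchanged, this pair shows that losing the benzyloxy group, with its 8 heavy atoms and six-membered aromatic ring, produces no change beyond the scatter at this position. No measurement is available that could explain this result.

The compounds shown leave open whether an amine, a carboxylic acid or a longer alkoxy chain at this position would move the number in this assay beyond the scatter, as this single pair compares only benzyloxy and hydrogen. They also leave open whether the same step would stay within the scatter with other side chains: compound 3, which also carries benzyloxy, gives "not active" (no number reported), and no single-change partner for it appears here.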